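The source may report more compounds than this note shows. Statements on the series, on what has been measured and on what is new or still open speak of the compounds shown alone.

Among the compounds with values here, compound 1 `COc1cc(C2CC(c3ccc(Br)cc3)=NN2C(C)=O)cc(OC)c1OC` gives 3450 nM in a functional assay on PC-3 cells (Homo sapiens) for cytotoxicity, read by sulforhodamine B assay, with a stated time of 48 h (on this read-out higher numbers stand for weaker inhibition and lower numbers for stronger inhibition), the lower of the two numbers measured so far. Compound 2 `CC(=O)N1N=C(c2ccco2)CC1c1ccc(N(C)C)cc1` gives 16700 nM in this assay, a gap beyond the scatter; since these two compounds differ in more than one place, their values are simply set side by side. Compound 3 `COc1cc(C2CC(c3ccco3)=NN2C(C)=O)cc(OC)c1OC` carries furan-2-yl in place of 4-bromophenyl on a carbon with a double bond to nitrogen, furan-2-yl in place of 4-bromophenyl on a carbon with a double bond to nitrogen. In this assay a modest step toward weaker inhibition is expected, a 2.3-fold higher number from compound 1 to compound 3 (0.37 log units; beyond the scatter). Compound 3 is estimated to give 8000 nM, in a range from 2500 nM to 25000 nM.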

Compound 3, half-maximal inhibitory concentration: 9650 nM
Estimate against measurement, compound 3: 1.2-fold (0.08 log units) below; the range from low to high includes it.
By their numbers in this assay, from the lowest: compound 1; then compounds 3 and 2 (each within the scatter of the next).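

In this assay, furan-2-yl in place of 4-bromophenyl on a carbon with a double bond to nitrogen gives a 2.8-fold higher number from compound 1 to compound 3 (0.45 log units; beyond the scatter), so the group at this position does change the read-out, though only modestly. With the smaller furan-2-yl ring, compound 3 still gives a measurable 9650 nM. Nothing available here explains the shift. The compounds shown leave open whether the bromine or the ring itself matters, as both change in this one step. A plain phenyl group at this position would separate the two.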